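The source may hold more compounds than are shown below. What is called first, only, known or untested is meant among the compounds shown, and "the series" means these compounds.

Measured compounds:
- compound 1 `COc1ccc2cc(C(C)c3nnc4n3N=C(c3ccc(C)cc3)CS4)ccc2c1`: 8200 nM
- compound 2 `Cc1ccc(C2=Nn3c(nnc3C(C)c3ccc(-c4ccccc4)c(F)c3)SC2)cc1`: 7200 nM
- compound 3 `CC(C)Cc1ccc(C(C)c2nnc3n2N=C(c2ccc(Br)cc2)CS3)cc1`: 4900 nM

The three compounds share a common core and were tested in a functional assay on Huh-7 cells (Homo sapiens) for inhibition, read by sulforhodamine B assay, with a stated time of 72 h; a higher number here means a weaker inhibitor, a lower number a stronger inhibitor. Compound 1 gives the highest of the three numbers in this assay, with 8200 nM. Its nearest neighbour is compound 2 at 7200 nM, and the furthest is compound 3 at 4900 nM; both of these gaps are within the usual scatter, so no order among the three can be claimed. For the measured compounds named here, compound 3 also carries a 4-bromophenyl group, but it differs from compound 1 elsewhere as well, so its value shows only that a bromo-bearing analogue of this core can sit in the same range.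

Compound 4 `COc1ccc2cc(C(C)c3nnc4n3N=C(c3ccc(Br)cc3)CS4)ccc2c1` has not yet been measured. It differs from compound 1 in one place: bromo in place of methyl on an aromatic carbon. Going by the values given here, no step between measured compounds isolates this change, so the expectation rests on the tight spread of the three values, all within scatter of one another. On that basis a step in this assay of no more than the scatter is expected, leaning slightly towards a lower number. Compound 4 is therefore estimated at 6000 nM, within a range of 2500 nM to 15000 nM, an expected step of a 1.4-fold lower number from compound 1 to compound 4 (0.14 log units; within the scatter).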

Compound 4, half-maximal inhibitory concentration: 9300 nM
The estimate for compound 4 lay 1.6-fold (0.19 log units) below the measured number; measured number inside the range.
By their numbers in this assay, from the lowest: compounds 3, 2, 1 and 4 (each within the scatter of the next).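

In this assay, for the compounds shown here, the change from 4-methylphenyl to 4-bromophenyl gives a 1.1-fold higher number from compound 1 to compound 4 (0.05 log units; within the scatter) and is the first comparison here that differs in one place only, so this position on the aromatic ring, para to a large group, can now be read directly. Going by these compounds alone, with the rest of compound 1 held fixed, bromo and methyl at this position cannot be told apart in this read-out, which the earlier compounds could not show, as each differs from the others in more than one place. Nothing available explains this result or ties it to any property of the two groups.

As far as these compounds go, whether an amine, a carboxylic acid or a longer chain at this position would give a step beyond the scatter in this assay remains open, as two groups with a single heavy atom each say little about larger ones. The other parts of the molecule also remain unresolved. Compound 2 and compound 3 differ from compound 1 in more than one place and so isolate no single change.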